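Shortening the cyclopropyl-bearing side chain on a potent core

This account rests on a few compounds, and the source may have more. Where it says the series, first, only, none or still open, it means among the compounds named here.

Compound 2 `CCc1nc2c(-c3ccc(OC)nc3C)ccnc2n1C(CC)C1CC1` carries a methyl group in place of the trifluoromethyl group of compound 1 `CCc1nc2c(-c3ccc(OC)nc3C(F)(F)F)ccnc2n1C(CC)C1CC1`. In an assay for binding affinity to Corticotropin releasing factor receptor (Rattus norvegicus) (a higher number here means a weaker inhibitor, a lower number a stronger inhibitor), compound 2 gives 0.7 nM, and compound 1 gives 0.7 nM. Going by the values given here, the single step recorded between them, no change at the digits printed from compound 1 to compound 2 (within the scatter), shows that this exchange on the aromatic carbon left the inhibition constant where it was.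

Compound 3 `CCc1nc2c(-c3ccc(OC)nc3C)ccnc2n1C(C)C1CC1` differs from compound 2 at another site: hydrogen in place of methyl on a saturated chain carbon, two bonds along the chain from an aromatic nitrogen and a saturated ring carbon. Read one bond further out, the change is ethyl to methyl, or 1-cyclopropylpropyl to 1-cyclopropylethyl. Among the compounds with values here, no measured step in this set touches that chain, so the only step available, from compound 1 to compound 2, does not bear on it directly; it shows only that the core tolerates a change elsewhere without loss. With no closer guide, the expectation for this assay is a small shift of a 2.1-fold higher number from compound 2 to compound 3 (0.33 log units; beyond the scatter), with a modest weakening the more likely direction. Compound 3 is therefore estimated at 1.5 nM, with a range from 0.5 nM to 5 nM.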

Compound 3, inhibition constant: 2 nM
Estimate against measurement, compound 3: 1.3-fold (0.12 log units) below, within the range that was stated.
By their numbers in this assay, from the lowest: compounds 1 and 2 (each within the scatter of the next); then compound 3.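

In this assay, shortening 1-cyclopropylpropyl to 1-cyclopropylethyl gives a 2.9-fold higher number from compound 2 to compound 3 (0.46 log units; beyond the scatter), so this saturated chain carbon is a place where a single change moves the number beyond the scatter, which the exchange of trifluoromethyl for methyl on the aromatic carbon did not do. The step is modest, and compound 3 still gives 2 nM, so the loss of this one methyl raises the number without abolishing binding in this series. Nothing among the data given accounts for the shift at this position.

As far as these compounds go, whether a longer chain than ethyl at this carbon, such as propyl or butyl, would lower the number further or raise it again stays open, as does whether the cyclopropyl ring could give way to an isopropyl or a phenyl group without cost. From the compounds shown here alone, it is also open whether the same shortening would give a step of similar size with trifluoromethyl on the aromatic carbon, as in compound 1, since the change is read here only with methyl in that place.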